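The source may report more compounds than this note shows. Statements on the series, on what has been measured and on what is new or still open speak of the compounds shown alone.

Compound 1 `CCC1=C(O)c2c(oc(-c3ccccc3)cc2=O)C(CC)(CC)C1=O` gives only a limit in a functional assay on KB cells (Homo sapiens) for antiproliferative activity, read by sulforhodamine B assay, with a stated time of 3 days; a lower number here means that less compound is needed, a higher number that more compound is needed for the effect: in this assay compound 1 reads > 236 uM, and (the limit of > 236 uM in this assay, at which 1 of the 3 values shown sits). Two relatives replace a hydrogen on an aromatic carbon. Compound 2 `CCCCc1ccc(-c2cc(=O)c3c(o2)C(CC)(CC)C(=O)C(CC)=C3O)cc1` gives 111 uM in this assay, and compound 3 `CCC1=C(O)c2c(oc(-c3ccc(OC(F)(F)F)cc3)cc2=O)C(CC)(CC)C1=O` gives 36.5 uM. The steps were an at least 2.1-fold lower number from compound 1 to compound 2 (0.32 log units; beyond the scatter) and an at least 6.4-fold lower number from compound 1 to compound 3 (0.81 log units; beyond the scatter), while between the two substituted analogues there was a 3.0-fold lower number from compound 2 to compound 3 (0.48 log units; beyond the scatter). Compound 4 `CCC1=C(O)c2c(oc(-c3ccc(F)cc3)cc2=O)C(CC)(CC)C1=O` carries the change (fluoro in place of hydrogen on an aromatic carbon). Both measured changes at that aromatic carbon gave lower numbers, so a lowering is expected for compound 4 as well, although its size is uncertain because the starting point is a limit (the limit of > 236 uM in this assay, at which 1 of the 3 values shown sits). Compound 4 is expected to give about 90 uM, within 30 uM to 236 uM, which would mean an at least 2.6-fold lower number from compound 1 to compound 4 (0.41 log units; beyond the scatter).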

Compound 4, concentration for half-maximal effect: 33 uM
Compound 4: middle estimate off by 2.7-fold (0.44 log units), on the high side, and the stated range covers the measured number.
By their numbers in this assay, from the lowest: compounds 4 and 3 (each within the scatter of the next); then compound 2. At a limit, above all of these: compound 1.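

Even fluoro, a single heavy atom, lowers the number in this assay, giving an at least 7.1-fold lower number from compound 1 to compound 4 (0.85 log units; beyond the scatter), and that size is only a bound, as compound 1 stands at a limit: the limit of > 236 uM in this assay, at which 1 of the 4 values shown sits. Fluoro and trifluoromethoxy cannot be told apart at this aromatic carbon, with a 1.1-fold lower number from compound 3 to compound 4 (0.04 log units; within the scatter). Fluoro also improves on butyl here, with a 3.4-fold lower number from compound 2 to compound 4 (0.53 log units; beyond the scatter). The compounds shown leave open whether an amine, a carboxylic acid or a chloro group on this carbon would also lower the number.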